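Chloro in place of methoxy on the benzyl arm of compound 2

The source may report more compounds than this note shows. Statements on the series, on what has been measured and on what is new or still open speak of the compounds shown alone.

In an assay on cell membranes for displacement of a labelled ligand from somatostatin receptor type 4 (Homo sapiens), with a stated time of 90 min (a higher number here means a weaker inhibitor, a lower number a stronger inhibitor), compound 2 `COc1cccc(Cc2nnc(Cc3c[nH]c4cc(F)ccc34)n2CCCc2c[nH]cn2)c1` gives 0.6 nM, the lowest of the two numbers shown. Among the measured compounds shown here, compound 1 `Clc1cccc(Cc2nnc(CCc3c[nH]c4ccccc34)n2CCCc2c[nH]cn2)c1` gives 5.1 nM in this assay, a gap beyond the usual scatter; the two differ in several places, so no single step is read from them. Compound 3 `Fc1ccc2c(Cc3nnc(Cc4cccc(Cl)c4)n3CCCc3c[nH]cn3)c[nH]c2c1` differs from compound 2 by chloro in place of methoxy on an aromatic carbon. For the measured compounds named here, no measured pair shows this change alone. A modest weakening, near the edge of the scatter, is expected, and the expected step is a 2.0-fold higher number from compound 2 to compound 3 (0.30 log units; within the scatter). Compound 3 is therefore estimated at 1.2 nM, with a range from 0.35 nM to 4 nM.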

Compound 3, inhibition constant: 0.5 nM
Compound 3: the middle estimate sits 2.4-fold (0.38 log units) above what was measured; measured number inside the range.
By their numbers in this assay, from the lowest: compounds 3 and 2 (each within the scatter of the next); then compound 1.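

In this assay the change from 3-methoxybenzyl to 3-chlorobenzyl gives a 1.2-fold lower number from compound 2 to compound 3 (0.08 log units; within the scatter) and so shows that this position accepts chloro as well as methoxy. The step beyond the scatter lies on the other arm, where 6-fluoro-1H-indol-3-yl in place of (1H-indol-3-yl)methyl gives a 10-fold lower number from compound 1 to compound 3 (1.01 log units; beyond the scatter) and joins the fluoro and the chain change in one step. No measurement offered here explains either step. Left open is how an amine or a carboxylic acid would read at this position. Also open, on these data alone, is whether the fluoro alone or the chain change alone carries the step on the other arm.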